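From compound 2 to compound 4: chloro for methoxy

A few compounds are considered here, and "the series" means these few. Any claim that something is new, unique, unknown or untested is made for them only; others in the source may bear on it.

In a functional assay on U-87MG ATCC cells for antiproliferative activity against U-87 MG (Homo sapiens), read by MTT assay, with a stated time of 48 h (a lower number here means a stronger inhibitor, a higher number a weaker inhibitor), compound 2 `COc1ccc(-c2nc(C)c(C(=O)CSc3nc(-c4cccc(OC)c4)c(C#N)c(=O)[nH]3)s2)cc1` gives 15300 nM, the lowest of three numbers, with compound 1 `COc1ccc(-c2nc(C)c(C(=O)CSc3nc(-c4ccc(Cl)cc4)c(C#N)c(=O)[nH]3)s2)cc1` at 45900 nM and compound 3 `COc1ccc(-c2nc(C)c(C(=O)CSc3nc(-c4ccc(Cl)c(Cl)c4)c(C#N)c(=O)[nH]3)s2)cc1` at 68500 nM. Compound 4 `COc1cccc(-c2nc(SCC(=O)c3sc(-c4ccc(Cl)cc4)nc3C)[nH]c(=O)c2C#N)c1` is unmeasured. It carries 4-chlorophenyl in place of 4-methoxyphenyl (chloro in place of methoxy on an aromatic carbon), chloro in place of methoxy on an aromatic carbon. Among the measured compounds shown here, no measured step tests this site. For the measured compounds named here, the closest evidence comes from a different site, where a 3.0-fold lower number from compound 1 to compound 2 (0.48 log units; beyond the scatter) and a 4.5-fold higher number from compound 2 to compound 3 (0.65 log units; beyond the scatter) both favour the methoxy-bearing group over the chloro-bearing ones, while a 1.5-fold higher number from compound 1 to compound 3 (0.17 log units; within the scatter) separates only two chloro-bearing groups. As far as these compounds go, whether this carries over is unknown. A modest 2.1-fold higher number from compound 2 to compound 4 (0.32 log units; beyond the scatter) is expected. Compound 4 is estimated at 32000 nM, with an expected range of 10000 nM to 90000 nM.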

Compound 4, half-maximal inhibitory concentration: 41000 nM
Beside the measured number, compound 4's estimate is 1.3-fold (0.11 log units) below it; the measured number falls inside the stated range.
By their numbers in this assay, from the lowest: compound 2; then compounds 4, 1 and 3 (each within the scatter of the next).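

In this assay, among the compounds shown here, this is the first reading at this position: going from 4-methoxyphenyl to 4-chlorophenyl gives a 2.7-fold higher number from compound 2 to compound 4 (0.43 log units; beyond the scatter), a modest step beyond the scatter. The methoxy-bearing compound holds the lower number here, as it does at the other aryl position in a 3.0-fold lower number from compound 1 to compound 2 (0.48 log units; beyond the scatter), and compound 2 remains the lowest of the four. No data given here account for the step.

One pair cannot show whether the methoxy itself matters or only its replacement by chloro. As far as these compounds go, an amine, a hydroxyl or a longer alkoxy chain at this position remains open, as does the same change with the other aryl groups of compound 1 and compound 3.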